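The source may hold more compounds than are shown below. What is called first, only, known or untested is meant among the compounds shown, and "the series" means these compounds.

Measured so far:
Compound 1 `Cc1nnsc1CO/N=C/c1c(C)nn(C)c1Oc1ccccc1Cl` gives in a functional assay on Huh-7 cells (Homo sapiens) for inhibition, read by MTT assay, with a stated time of 48 h (a lower number here means a stronger inhibitor, a higher number a weaker inhibitor), the value > 50000 nM, which is a limit of the assay and not a number.
Compound 2 `Cc1nnsc1CO/N=C/c1c(C)nn(C)c1Oc1ccccc1OC(F)(F)F` gives in this assay the value > 50000 nM, likewise a limit.

Among the compounds with values here, compound 1 thus stands only at a limit, and so does the one other measured compound. The step that the two limits leave unreadable from compound 1 to compound 2 cannot be read, since (the limit of > 50000 nM in this assay, at which 2 of the 2 values shown sit). Compound 3 `Cc1nnsc1CO/N=C/c1c(C)nn(C)c1Cl` differs from compound 1 by chloro in place of 2-chlorophenoxy on an aromatic carbon. Within the data shown here, no measured step covers this change, and the single measured step is unreadable, so no direction of change in this assay can be predicted. Compound 3 is therefore estimated at 50000 nM, between 10000 nM and 200000 nM, an expected step of a number no higher from compound 1 to compound 3 (the limit leaves the size open) of no readable size, most likely again reported only as a limit.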

Compound 3, half-maximal inhibitory concentration: > 50000 nM
Compound 3: a limit, no number (the forecaster's own chance of this, stated with the estimate: 80%); the middle value lies on the limit itself.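

The step from compound 1 to compound 3 cannot be read, since both values are limits and not numbers: the limit of > 50000 nM in this assay, at which 3 of the 3 values shown sit. The compounds shown leave open how strongly any of them acts in this assay and whether swapping 2-chlorophenoxy for chloro changes that at all.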